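Aryl Swap on the Ring Nitrogen: Expecting Compound 4

The source may hold more compounds than are shown below. What is called first, only, known or untested is meant among the compounds shown, and "the series" means these compounds.

In a functional assay on CHO cells with adenosine receptor A1 (Homo sapiens) as the target, read by cAMP accumulation and immunoassay, with a stated time of 6 min, tested at 0.1 uM (a higher number here means a weaker effect of the compound at the concentration tested, a lower number a stronger effect), the three measured compounds gave:
compound 1, `Nc1scc(CN2CCN(c3ccc(Cl)cc3Cl)CC2)c1C(=O)c1ccc(Cl)cc1`: -11%
compound 2, `Nc1scc(CN2CCN(c3cccc(Cl)c3Cl)CC2)c1C(=O)c1ccc(Cl)cc1`: 3.2%
compound 3, `Nc1scc(CN2CCN(c3cccnc3)CC2)c1C(=O)c1ccc(Cl)cc1`: 3.4%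

Compound 3 holds the highest of the three numbers in this assay, with compound 2 next, within the scatter, and compound 1 furthest, beyond it. Compound 4, `Nc1scc(CN2CCN(c3cc(F)cc(F)c3)CC2)c1C(=O)c1ccc(Cl)cc1`, differs from compound 3 by 3,5-difluorophenyl in place of pyridin-3-yl on an amine nitrogen in a ring. Within the data shown here, the steps that bear on it are the other aryl swaps at the same ring nitrogen: a number 14.4 percentage points higher from compound 1 to compound 3 (beyond the scatter) and a number 0.2 percentage points higher from compound 2 to compound 3 (within the scatter), one modest, one within the scatter. Among the measured compounds shown here, no measured step involves 3,5-difluorophenyl, so the expectation is a step no larger than the scatter: a number 1.4 percentage points lower from compound 3 to compound 4 (within the scatter). Compound 4 is therefore estimated at 2%, between -12% and 14%.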

Compound 4, a percentage reported as activity, at one concentration (the size of the read-out at that concentration, not a potency): -5%
For compound 4 the middle estimate is 7 percentage points above the measured one, within the range that was stated.
By their numbers in this assay, from the lowest: compounds 1, 4, 2 and 3 (each within the scatter of the next, the first and the last beyond it).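

In this assay, 3,5-difluorophenyl on the amine nitrogen gives a number 8.4 percentage points lower from compound 3 to compound 4 (within the scatter) and a number 8.2 percentage points lower from compound 2 to compound 4 (within the scatter) and a number 6 percentage points higher from compound 1 to compound 4 (within the scatter) without any of these steps leaving the scatter. The hetero atom of pyridin-3-yl is therefore not required here, as an aromatic ring of carbon only gives a step that cannot be told from scatter. Compound 4 also links compound 1 and compound 3, whose own gap lies beyond the scatter, and nothing available explains these values. Open, going by these compounds, is whether a methoxyphenyl, a nitrile-bearing phenyl or a saturated cyclohexyl group at this nitrogen would stay within the scatter of compound 4.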